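A Chloro Joins the Phenyl of Compound 3

The source may report more compounds than this note shows. Statements on the series, on what has been measured and on what is new or still open speak of the compounds shown alone.

Three compounds have numbers in a functional assay on HepG2 cells (Homo sapiens) for cytotoxicity, read by sulforhodamine B assay, with a stated time of 48 h; a higher number here means a weaker inhibitor, a lower number a stronger inhibitor:
compound 1, `C/C(=N\NC(=O)CC#N)c1ccc(NS(=O)(=O)c2ccc(Cl)cc2)cc1`: 8000 nM
compound 2, `CSC(SC)=C(C#N)C(=O)N/N=C(\C)c1ccc(NS(=O)(=O)c2ccc(Cl)cc2)cc1`: 19400 nM
compound 3, `CCOC(=O)c1c(-c2ccccc2)c(C#N)c(=O)n(/N=C(\C)c2ccc(NS(=O)(=O)c3ccc(Cl)cc3)cc2)c1N`: 16800 nM

Compound 3 holds the second highest number of the three; compound 2 is its nearest neighbour, within the scatter, and compound 1 its furthest, beyond the scatter. Compound 4, `CCOC(=O)c1c(-c2ccccc2Cl)c(C#N)c(=O)n(/N=C(\C)c2ccc(NS(=O)(=O)c3ccc(Cl)cc3)cc2)c1N`, differs from compound 3 in one place: chloro in place of hydrogen on an aromatic carbon. Among the measured compounds shown here, the single measured step, a 2.4-fold higher number from compound 1 to compound 2 (0.38 log units; beyond the scatter), alters the group on the carbonyl carbon, a quite different part of the shared core, so no measured step bears on this chloro-for-hydrogen change. With nothing to point either way, the expected step is none beyond the scatter, a 1.0-fold higher number from compound 3 to compound 4 (0.01 log units; within the scatter). Compound 4 is therefore estimated at 17000 nM, with a range from 8000 nM to 36000 nM.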

Compound 4, half-maximal inhibitory concentration: 11400 nM
For compound 4 the middle estimate is 1.5-fold (0.17 log units) above the measured one; measured number inside the range.
By their numbers in this assay, from the lowest: compounds 1, 4, 3 and 2 (each within the scatter of the next, the first and the last beyond it).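

In this assay phenyl to 2-chlorophenyl gives a 1.5-fold lower number from compound 3 to compound 4 (0.17 log units; within the scatter) and so this read-out does not tell the two compounds apart. The earlier compounds shown here said nothing about this aromatic carbon, ortho to a large group, and here chloro takes the place of hydrogen without a step beyond the scatter. No evidence is available on the reason for this result.

Going by these compounds, whether a methoxy group or an amine on this carbon would also stay within the scatter remains open. A single substituent at this place gives no trend.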